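Aryl thioether variation at the nucleoside core

The compounds below may be only part of what the source reports. "The series", "measured", "known", "first", "only" and "open" are said of these compounds alone.

Compound 1 `OC[C@H]1O[C@@H](n2cnc3c(CSc4ccc(Cl)c(Cl)c4)ncnc32)[C@H](O)[C@@H]1O`: 224 nM in an assay on isolated protein for binding affinity to Equilibrative nucleoside transporter 1 (Homo sapiens); on this read-out lower numbers stand for stronger inhibition and higher numbers for weaker inhibition; compound 2 `O=[N+]([O-])c1cccc(SCc2ncnc3c2ncn3[C@@H]2O[C@H](CO)[C@@H](O)[C@H]2O)c1`: 4.79 nM.

On the numbers shown, compound 2 gives the lowest number; its nearest neighbour is compound 1, reached by a 47-fold lower number from compound 1 to compound 2 (1.67 log units; beyond the scatter). Compound 3 `COC(=O)c1ccc(SCc2ncnc3c2ncn3[C@@H]2O[C@H](CO)[C@@H](O)[C@H]2O)cc1` differs from compound 2 by 4-(methoxycarbonyl)phenyl in place of 3-nitrophenyl on a sulfur. Among the compounds with values here, the only measured step, the one from compound 1 to compound 2, changes the aryl group on the same sulfur and is large, so a sizeable shift is possible in either direction. For compound 3 a weaker result than compound 2 is expected, a step of a 6.3-fold higher number from compound 2 to compound 3 (0.80 log units; beyond the scatter), with the estimate 30 nM and a range from 5 nM to 300 nM.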

Compound 3, half-maximal inhibitory concentration: 813 nM
Beside the measured number, compound 3's estimate is 27-fold (1.43 log units) below it; the whole stated range lies below it.
By their numbers in this assay, from the lowest: compound 2; then compound 1; then compound 3.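

With a 170-fold higher number from compound 2 to compound 3 (2.23 log units; beyond the scatter) and a 3.6-fold higher number from compound 1 to compound 3 (0.56 log units; beyond the scatter) the aryl group on this sulfur is seen to move the number upward as well as downward. A low number is therefore not shared by every aryl group here: 3-nitrophenyl and 4-(methoxycarbonyl)phenyl carry the same counts of hydrogen-bond donors and acceptors, yet that match does not keep compound 3 near compound 2.

From the compounds shown here alone, whether a carboxylic acid or an amine on the aryl ring would fall nearer compound 2 or compound 3 stays open. No evidence at hand accounts for these gaps.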